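The source may hold more compounds than are shown below. What is called first, only, known or untested is meant among the compounds shown, and "the series" means these compounds.

Measured so far:
compound 1 `CCC(C)OC(=O)/C=C(C)/C=C/CC(C)CCCC(C)C` — 7.69
compound 2 `CCC(C)OC(=O)/C=C(C)/C=C/CC(C)CCCC(C)(C)OC` — 6.49
compound 3 `COC(C)(C)C(O)CCC(C)C/C=C/C(C)=C/C(=O)OC(C)C` — 3.86

In a physicochemical assay for lipophilicity (on this read-out lower numbers stand for lower lipophilicity and higher numbers for higher lipophilicity), compound 1 stands highest of the three, compound 2 coming nearest and compound 3 lying furthest below it. Compound 4 `CC(/C=C/CC(C)CCCC(C)C)=C\C(=O)SC(C)C` differs from compound 1 in one place: isopropylsulfanyl in place of sec-butoxy on a carbonyl carbon. Among the measured compounds shown here, no measured step touches this kind of change; the only step seen, a number 1.20 log units lower from compound 1 to compound 2 (beyond the scatter), concerns a methoxy group added elsewhere on the chain and says nothing about swapping the group on the carbonyl carbon. With one carbon fewer but a sulfur in place of an oxygen, the step is expected to be small and within the scatter. Compound 4 is therefore estimated to give 7.8 in this assay, in the range 7.2 to 8.4, a step of a number 0.11 log units higher from compound 1 to compound 4 (within the scatter).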

Compound 4, partition coefficient: 8.39
Estimate against measurement, compound 4: 0.59 log units below; the range from low to high includes it.
By their numbers in this assay, from the lowest: compound 3; then compound 2; then compound 1; then compound 4.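

In this assay, the group on the carbonyl carbon proves able to move the number upward: isopropylsulfanyl in place of sec-butoxy gives a number 0.70 log units higher from compound 1 to compound 4 (beyond the scatter). Among the compounds shown here, the only earlier single change, methoxy on the chain, went the other way, with a number 1.20 log units lower from compound 1 to compound 2 (beyond the scatter). Nothing available explains the rise at the carbonyl carbon.

Going by these compounds, this swap changes both the oxygen-to-sulfur link and the carbon chain at once, so the share of each stays unknown. On these data alone, how sec-butylsulfanyl, an amine or a carboxylic acid would read on this carbonyl carbon remains open.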